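The source may report more compounds than this note shows. Statements on the series, on what has been measured and on what is new or still open speak of the compounds shown alone.

Compound 1 `NCCCc1nnc(CCc2c[nH]c3ccccc23)n1Cc1ccccc1`: > 10000 nM
Compound 2 `NCCCc1nnc(CCc2c[nH]c3ccccc23)n1Cc1ccc(Cl)c(Cl)c1`: > 10000 nM

In an assay on cells for displacement of a labelled ligand from somatostatin receptor type 2 (Homo sapiens), with a stated time of 90 min (a higher number here means a weaker inhibitor, a lower number a stronger inhibitor), compound 1 gives > 10000 nM, which is a limit of the assay. Compound 2 gives > 10000 nM, likewise a limit. The step that the two limits leave unreadable from compound 1 to compound 2 therefore cannot be read, since both values sit at the limit of > 10000 nM in this assay, at which 2 of the 2 values shown sit. Compound 3 `Clc1ccc(Cn2c(CCc3c[nH]c4ccccc34)nnc2C2CCNCC2)cc1Cl` differs from compound 2 by piperidin-4-yl in place of 3-aminopropyl on an aromatic carbon. Within the data shown here, no measured step bears on this change, and compound 2 itself stands only at a limit, so no direction can be inferred. The expected step of an at least 1.2-fold lower number from compound 2 to compound 3 (0.09 log units; that floor lies within the scatter) is thus uncertain. Compound 3 is estimated at 8000 nM, in the range 1500 nM to 30000 nM.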

Compound 3, inhibition constant: > 10000 nM
Compound 3 ended at the assay's limit; the forecaster's own chance of this, stated with the estimate: 65%; at least 1.2-fold (0.09 log units) between middle value and limit.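

No step can be read between compound 2 and compound 3, since both stand only at a limit of the assay: the limit of > 10000 nM in this assay, at which 3 of the 3 values shown sit. The compounds shown leave open how strong an inhibitor each is in this assay, and whether either change has any effect.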